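Replacing a naphthyl amide with a methoxycinnamoyl amide

The source may report more compounds than this note shows. Statements on the series, on what has been measured and on what is new or still open speak of the compounds shown alone.

Measured compounds:
compound 1, `CN1[C@@H]2c3[nH]c4ccccc4c3C[C@H]1[C@H](C#N)N1[C@@H](CNC(=O)c3ccc(Cl)cc3)c3[nH]c4ccccc4c3C[C@@H]21`, 130 nM
compound 2, `CN1[C@@H]2c3[nH]c4ccccc4c3C[C@H]1[C@H](C#N)N1[C@@H](CNC(=O)c3ccc4ccccc4c3)c3[nH]c4ccccc4c3C[C@@H]21`, 4940 nM
compound 3, `CN1[C@@H]2c3[nH]c4ccccc4c3C[C@H]1[C@H](C#N)N1[C@@H](CNC(=O)/C=C/c3ccccc3)c3[nH]c4ccccc4c3C[C@@H]21`, 1400 nM

Three amides of a shared core have been tested in a functional assay on HT-29 cells (Homo sapiens) for cytotoxicity, read by MTT assay, with a stated time of 72 h; a lower number here means a stronger inhibitor, a higher number a weaker inhibitor. Compound 2 stands highest of the three numbers: its nearest neighbour is compound 3, and the step of a 3.5-fold lower number from compound 2 to compound 3 (0.55 log units; beyond the scatter), while the step of a 38-fold higher number from compound 1 to compound 2 (1.58 log units; beyond the scatter) is the largest gap in the set. Compound 1 gives the lowest number, and the step of an 11-fold higher number from compound 1 to compound 3 (1.03 log units; beyond the scatter) separates it from compound 3.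

Compound 4, `COc1ccc(/C=C/C(=O)NC[C@H]2c3[nH]c4ccccc4c3C[C@H]3[C@H]4c5[nH]c6ccccc6c5C[C@@H]([C@H](C#N)N23)N4C)cc1`, has not yet been measured in this assay. It differs from compound 2 in one place: 2-(4-methoxyphenyl)ethenyl in place of naphthalen-2-yl on a carbonyl carbon. The step that bears most directly on this change is a 3.5-fold lower number from compound 2 to compound 3 (0.55 log units; beyond the scatter), where the same kind of exchange, a phenylethenyl group for the naphthalen-2-yl group, lowered the number by a modest amount. Among the compounds with values here, compound 4 carries an added methoxy group on that phenylethenyl piece, and no measured pair here speaks to that addition on its own.

Compound 4 is therefore expected to give a step of a 3.3-fold lower number from compound 2 to compound 4 (0.52 log units; beyond the scatter) in this assay. For compound 4 the estimate is 1500 nM, with a range from 500 nM to 5000 nM.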

Compound 4, half-maximal inhibitory concentration: 3060 nM
Estimate against measurement, compound 4: 2.0-fold (0.31 log units) below, and the stated range covers the measured number.
By their numbers in this assay, from the lowest: compound 1; then compound 3; then compounds 4 and 2 (each within the scatter of the next).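

In this assay, the exchange of naphthalen-2-yl for 2-(4-methoxyphenyl)ethenyl on a carbonyl carbon gives a 1.6-fold lower number from compound 2 to compound 4 (0.21 log units; within the scatter), so at this position the two groups cannot be told apart, even though one has two aromatic rings and the other has one ring with a double bond outside it. The added methoxy gets its first direct reading in a 2.2-fold higher number from compound 3 to compound 4 (0.34 log units; beyond the scatter): on the phenylethenyl group, methoxy in place of hydrogen moves the number modestly upward rather than lowering it further, and a 24-fold higher number from compound 1 to compound 4 (1.37 log units; beyond the scatter) leaves the 4-chlorophenyl amide, compound 1, well clear of the methoxy-bearing amide. Nothing at hand explains these steps.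

Going by these compounds, what a plain phenyl or a 4-methoxyphenyl group directly on the carbonyl carbon would give remains open, and so does whether the chlorine or the absence of the ethenyl piece goes with the low number of compound 1. A 2-(4-chlorophenyl)ethenyl group at this position would separate those two features, and a single methoxy reading cannot show how other groups on that ring would behave.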